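Methoxy for isopropyl on a methylated flavone acid

The source may hold more compounds than are shown below. What is called first, only, known or untested is meant among the compounds shown, and "the series" means these compounds.

Measured compounds:
- compound 1, `CC(C)c1ccc(-c2oc3ccc(C(=O)O)cc3c(=O)c2O)cc1`: 24%
- compound 2, `COc1ccc(-c2oc3ccc(C(=O)O)cc3c(=O)c2O)cc1`: 24%
- compound 3, `COc1c(-c2ccc(C(C)C)cc2)oc2ccc(C(=O)O)cc2c1=O`: 18%

In a functional assay on the whole organism (stomach) for inhibition, with Rattus norvegicus as the target, at a dose of 80 mg/kg (a lower number here means less inhibition, a higher number more inhibition at the dose given (going by the name of the read-out)), compound 1 gives 24%. Compound 2 differs from it by methoxy in place of isopropyl on an aromatic carbon, and the result is no change at the digits printed from compound 1 to compound 2 (within the scatter); in this assay compound 2 gives 24%. Compound 3 differs from compound 1 by methyl in place of hydrogen on an oxygen on an aromatic ring, and here the step is a number 6 percentage points lower from compound 1 to compound 3 (within the scatter), so that compound 3 gives 18% in this assay. All three numbers lie within the scatter of one another, so the inhibition in this assay is level across compound 1, compound 2 and compound 3.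

Compound 4, `COc1ccc(-c2oc3ccc(C(=O)O)cc3c(=O)c2OC)cc1`, has not been measured in this assay. It differs from compound 3 by methoxy in place of isopropyl on an aromatic carbon, the same change that turns compound 1 into compound 2, made on the core of compound 3 rather than on the core of compound 1; the difference between those two cores is the one described above as methyl in place of hydrogen on an oxygen on an aromatic ring. Since the earlier step, no change at the digits printed from compound 1 to compound 2 (within the scatter), left the inhibition essentially where it was, the step from compound 3 to compound 4 is expected to be small as well, namely no change at the digits printed from compound 3 to compound 4 (within the scatter). Going by the values given here, compound 4 is therefore estimated to give 18% in this assay, with a likely range from 8% to 28%, resting on the single earlier pair, compound 1 and compound 2.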

Compound 4, a percentage reported as inhibition, in the whole organism at one dose (the size of the read-out at that dose, not a potency): 22%
Beside the measured number, compound 4's estimate is 4 percentage points below it; the measured number falls inside the stated range.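

In this assay, methoxy in place of isopropyl on the core of compound 3 gave a number 4 percentage points higher from compound 3 to compound 4 (within the scatter), which matches the earlier step on the core of compound 1: the same change on two cores in this assay, no change at the digits printed (within the scatter) from compound 1 to compound 2 and a number 4 percentage points higher (within the scatter) from compound 3 to compound 4, 4 percentage points apart, within the scatter of two such steps. Methyl in place of hydrogen on an oxygen, carried onto the methoxy-bearing core, gave a number 2 percentage points lower from compound 2 to compound 4 (within the scatter), and this too matches its earlier counterpart: the same change on two cores in this assay, a number 6 percentage points lower (within the scatter) from compound 1 to compound 3 and a number 2 percentage points lower (within the scatter) from compound 2 to compound 4, 4 percentage points apart, within the scatter of two such steps. Both changes therefore carried from one core to the other without a difference that can be told apart in this assay, but every step among these compounds lies within the scatter, so the agreement is between steps that cannot themselves be told from no change, and it does not show that a larger effect would carry over or that either change would behave alike on a further core.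

The compounds shown leave open what an amine, a halogen or a longer chain would do in place of the isopropyl or methoxy. They also leave open what an ethyl or benzyl group on that oxygen would do in place of the methyl, and how the inhibition would run at another dose.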